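Dropping One Ring Chlorine From Compound 2

The source may hold more compounds than are shown below. What is called first, only, known or untested is meant among the compounds shown, and "the series" means these compounds.

Of the two compounds measured in a functional assay on the whole organism for inhibition, with Mus musculus as the target (a lower number here means that less compound is needed, a higher number that more compound is needed for the effect), compound 2 `CN(C(=O)CNC(=O)CN)c1ccc(Cl)cc1C(=O)c1ccccc1Cl` stands lowest: compound 2 gives 1.4 mg/kg, while compound 1 `NCC(=O)NCc1nncn1-c1ccc(Cl)cc1C(=O)c1ccccc1` gives 31.7 mg/kg, a gap well beyond the usual scatter. Compound 3 `CN(C(=O)CNC(=O)CN)c1ccc(Cl)cc1C(=O)c1ccccc1` differs from compound 2 in a single place: hydrogen in place of chloro on an aromatic carbon. For the measured compounds named here, no measured pair here isolates this change, so its size is open; compound 1 lacks the same chloro but rests on a different core. The expected step is a modest rise in dose, estimated as a 2.5-fold higher number from compound 2 to compound 3 (0.40 log units; beyond the scatter). Compound 3 is estimated to give about 3.5 mg/kg, between 1.2 mg/kg and 12 mg/kg, in this assay.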

Compound 3, dose for half-maximal effect: 15.2 mg/kg
Beside the measured number, compound 3's estimate is 4.3-fold (0.64 log units) below it, and the stated range ends below it.
By their numbers in this assay, from the lowest: compound 2; then compound 3; then compound 1.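

In this assay, for the compounds shown here, the change from 2-chlorophenyl to phenyl gives an 11-fold higher number from compound 2 to compound 3 (1.04 log units; beyond the scatter) on an otherwise unchanged structure, the first direct reading of this position. A single chlorine atom on this aromatic carbon, ortho to a large group, therefore accounts for a large part of the low dose of compound 2. Nothing shown here explains the size of this step. Still open, as far as these compounds go, is whether fluoro, methyl or methoxy at this place would keep the dose as low as chloro does.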